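The source may hold more compounds than are shown below. What is called first, only, known or untested is meant among the compounds shown, and "the series" means these compounds.

Among the compounds with values here, compound 2 `Cc1ccc(-n2cc(NC(=O)c3ccc(NS(=O)(=O)c4ccccc4)cc3)cn2)cc1` stands with the lowest of the two numbers measured so far in a functional assay on A549 cells (Homo sapiens) for inhibition, read by MTT assay, with a stated time of 48 h (on this read-out higher numbers stand for weaker inhibition and lower numbers for stronger inhibition), giving 54700 nM, although compound 1 `O=C(Nc1cnn(-c2ccccc2)c1)c1ccc(NS(=O)(=O)c2ccccc2)cc1`, which gives 87100 nM, lies within the scatter of it. Compound 3 `COc1cccc(-n2cc(NC(=O)c3ccc(NS(=O)(=O)c4ccccc4)cc3)cn2)c1` differs from compound 2 in one place: 3-methoxyphenyl in place of 4-methylphenyl on an aromatic nitrogen. Within the data shown here, the only measured step touching that aromatic ring, a 1.6-fold lower number from compound 1 to compound 2 (0.20 log units; within the scatter), stayed within the scatter, so a further change on the same ring is expected to shift the number little, if at all. Compound 3 is therefore estimated at 55000 nM, with a range from 25000 nM to 120000 nM. That estimate means an expected step of a 1.0-fold higher number from compound 2 to compound 3 (0.00 log units; within the scatter).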

Compound 3, half-maximal inhibitory concentration: > 100000 nM
Compound 3 ended at the assay's limit; the forecaster's own chance of this, stated with the estimate: 10%; at least 1.8-fold (0.25 log units) between middle value and limit.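

In this assay compound 3 gives a limit of the assay, not a number: the limit of > 100000 nM in this assay, at which 1 of the 3 values shown sits. Only floors can therefore be read, an at least 1.8-fold higher number from compound 2 to compound 3 (0.26 log units; that floor lies within the scatter) and an at least 1.1-fold higher number from compound 1 to compound 3 (0.05 log units; that floor lies within the scatter). Going by these compounds, on this aromatic nitrogen, 3-methoxyphenyl in place of 4-methylphenyl gives no sign of stronger inhibition, but the true size of the step stays unknown.

On these data alone, it remains open whether any group at this position can lower the number beyond the scatter. An aminophenyl or a carboxyphenyl group on this nitrogen might show that.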